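Trimming the amide aryl group of an inactive sulfone

The source may report more compounds than this note shows. Statements on the series, on what has been measured and on what is new or still open speak of the compounds shown alone.

Compound 1, `COc1ccc(CS(=O)(=O)CC(=O)Nc2c(C)cc(C)cc2C)cc1[N+](=O)[O-]`: > 30000 nM
Compound 2, `COc1ccc(CS(=O)(=O)CC(=O)Nc2c(C)cc(C)cc2C)cc1N`: > 30000 nM
Compound 3, `COc1cc(OC)c(/C=C/[S+]([O-])Cc2ccc(OC)c(N)c2)c(OC)c1`: < 10 nM

Within the data shown here, every number so far in a functional assay on MDA-MB-468 cells (Homo sapiens) for cytotoxicity, read by MTT assay, with a stated time of 72 h (on this read-out lower numbers stand for stronger inhibition of growth and higher numbers for weaker inhibition of growth), is a limit of the assay rather than a measured value. Compound 1 stands at > 30000 nM, which is a limit. Compound 2 also gives > 30000 nM, a limit. Compound 3, built on a different core, gives < 10 nM, a limit as well. Where compound 1 stands is therefore told only by the limit of > 30000 nM in this assay, at which 2 of the 3 values shown sit, while the limit of < 10 nM in this assay, at which 1 of the 3 values shown sits, belongs to a compound of another scaffold.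

Compound 4, `COc1ccc(CS(=O)(=O)CC(=O)Nc2ccccc2)cc1[N+](=O)[O-]`, differs from compound 1 by phenyl in place of 2,4,6-trimethylphenyl on an amide-type nitrogen. Among the measured compounds shown here, the single measured step from compound 1 is a step that the two limits leave unreadable from compound 1 to compound 2, which concerns a different part of the molecule and cannot be read. Nothing measured speaks for or against the change of the amide aryl group.

The expectation rests on the two limits of the shared core. Compound 4 is expected to remain at the limit, so the step of a number no higher from compound 1 to compound 4 (the limit leaves the size open) is estimated to show no readable change. The estimate for compound 4 is 30000 nM, with a range from 8000 nM to 100000 nM.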

Compound 4, concentration for 50% growth inhibition: > 30000 nM
Compound 4: a limit, no number (the forecaster's own chance of this, stated with the estimate: 80%); the middle value lies on the limit itself.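

In this assay compound 4 gives > 30000 nM, which is a limit of the assay. Among these compounds, compound 1 gives > 30000 nM, also a limit, so no step between compound 1 and compound 4 can be read. The compounds shown leave open whether phenyl and 2,4,6-trimethylphenyl on the amide-type nitrogen differ at all in growth inhibition.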